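A few compounds are considered here, and "the series" means these few. Any claim that something is new, unique, unknown or untested is made for them only; others in the source may bear on it.

Measured compounds:
compound 1 `CCN1CCc2c(sc(NC(=O)Nc3ccc(Cl)cc3)c2C#N)C1` — > 25000 nM
compound 2 `CC(C)(C)OC(=O)CCCCN1CCc2c(sc(NC(=O)Nc3ccc(Cl)cc3)c2C(N)=O)C1` — 710 nM

In a functional assay (strain AB) with Danio rerio as the target, read by microscopy, with a stated time of 1 h (a lower number here means that less compound is needed, a higher number that more compound is needed for the effect), compound 1 gives only a limit of the assay, > 25000 nM. That is the limit of > 25000 nM in this assay, at which 1 of the 2 values shown sits, so compound 1 stands at the limit, with no number. Compound 2 gives 710 nM in this assay. Compound 3 is `CCN1CCc2c(sc(NC(=O)Nc3ccc(Cl)cc3)c2C(=O)NC2COC2)C1`; it differs from compound 1 by (oxetan-3-yl)carbamoyl in place of cyano on an aromatic carbon. Within the data shown here, no single step between measured compounds covers this change, and the values of compound 1 and compound 2 are what the measured picture offers. Compound 3 is expected to gain beyond the scatter, with an expected step of an at least 8.3-fold lower number from compound 1 to compound 3 (0.92 log units; beyond the scatter). Compound 3 is estimated at 3000 nM, in a range from 500 nM to 20000 nM.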

Compound 3, half-maximal effective concentration: > 25000 nM
Compound 3 gave a limit, no number; the forecaster's own chance of this, stated with the estimate: 25%; middle value at least 8.3-fold (0.92 log units) from the limit.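

Compound 1 and compound 3 both stand at the limit in this assay, so no step between them can be read: the limit of > 25000 nM in this assay, at which 2 of the 3 values shown sit.

The compounds shown leave open whether (oxetan-3-yl)carbamoyl in place of cyano changes the effect at all.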